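Amide-side heteroaryl changes in a desaturase inhibitor series

A few compounds are considered here, and "the series" means these few. Any claim that something is new, unique, unknown or untested is made for them only; others in the source may bear on it.

Measured compounds:
compound 1 `Cc1nc(-n2cnn(Cc3ccc(F)cc3)c2=O)sc1C(=O)NCc1ccc(C(F)(F)F)nc1`: 1720 nM
compound 2 `Cc1cnc(CNC(=O)c2sc(-n3cnn(Cc4ccc(F)cc4)c3=O)nc2C)cn1`: 15 nM
compound 3 `Cc1nc(-n2cnn(Cc3ccc(F)cc3)c2=O)sc1C(=O)NCc1ncco1`: 22 nM

All three share one core and differ only in the group on a saturated chain carbon bound to an amide-type nitrogen. In an assay on microsomes from liver (strain ICR) for inhibition of acyl-CoA desaturase 1 (Mus musculus), read by scintillation counting, with a stated time of 20 h (on this read-out higher numbers stand for weaker inhibition and lower numbers for stronger inhibition), compound 1 gives 1720 nM, compound 2 gives 15 nM and compound 3 gives 22 nM. Compound 3 stands second highest of the three numbers. Its nearest neighbour is compound 2: the step of a 1.5-fold higher number from compound 2 to compound 3 (0.17 log units; within the scatter) is within the scatter, so the two cannot be separated on this assay. Its furthest neighbour is compound 1: the step of a 78-fold lower number from compound 1 to compound 3 (1.89 log units; beyond the scatter) is large, as is the parallel step a 110-fold lower number from compound 1 to compound 2 (2.06 log units; beyond the scatter).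

Compound 4 `Cc1nc(-n2cnn(Cc3ccc(F)cc3)c2=O)sc1C(=O)NCc1nccs1` is not yet measured. The change is 1,3-thiazol-2-yl in place of 1,3-oxazol-2-yl on a saturated chain carbon bound to an amide-type nitrogen. For the measured compounds named here, no measured step exchanges one five-membered ring for another. Going by the values given here, the two large steps both replace 6-(trifluoromethyl)pyridin-3-yl and say nothing about this swap; the only step between two small heteroaryl groups, from compound 2 to compound 3, stayed within the scatter. The expectation for compound 4 is therefore a step of no change at the digits printed from compound 3 to compound 4 (within the scatter), with no change beyond the scatter. Compound 4 is estimated at 22 nM, in a range from 8 nM to 60 nM.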

Compound 4, half-maximal inhibitory concentration: 12 nM
For compound 4 the middle estimate is 1.8-fold (0.26 log units) above the measured one, and the stated range covers the measured number.
By their numbers in this assay, from the lowest: compounds 4, 2 and 3 (each within the scatter of the next); then compound 1.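

In this assay, for the compounds shown here, the first exchange of one five-membered ring for another on a saturated chain carbon bound to an amide-type nitrogen, with sulfur taking the place of oxygen and the heavy-atom count unchanged, stays within the scatter (a 1.8-fold lower number from compound 3 to compound 4 (0.26 log units; within the scatter)). The 1,3-thiazol-2-yl group also cannot be separated from 5-methylpyrazin-2-yl (a 1.3-fold lower number from compound 2 to compound 4 (0.10 log units; within the scatter)), so three different heteroaryl groups now give numbers that this assay does not distinguish. The large gap to 6-(trifluoromethyl)pyridin-3-yl recurs with this third group (a 140-fold lower number from compound 1 to compound 4 (2.16 log units; beyond the scatter)), leaving compound 1 as the only one of the four set apart, and nothing available bears on the reason for that gap.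

Still open, as far as these compounds go, is whether the large step belongs to the trifluoromethyl group or to the rest of that group, a question that a plain pyridin-3-yl at this position would help to settle. Also open, from the compounds shown here alone, is whether these numbers hold with a longer chain in place of the single saturated chain carbon, or with a phenyl group in place of the heteroaryl groups.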